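The source may hold more compounds than are shown below. What is called first, only, known or untested is meant among the compounds shown, and "the series" means these compounds.

Measured compounds:
compound 1 `O=C1c2ccccc2S(=O)(=O)N1CCCCCCN1CCN(c2ccccc2F)CC1` gives 322 nM in an ADME assay on HEK293 cells for displacement of a labelled ligand from 5-hydroxytryptamine receptor 7 (Homo sapiens), read by radioligand binding, with a stated time of 1 h; a lower number here means a stronger inhibitor, a higher number a weaker inhibitor
compound 2 `O=C1c2ccccc2S(=O)(=O)N1CCCCCCN1CCN(c2cccc3cccnc23)CC1` gives 21 nM in this assay

Within the data shown here, compound 1 stands highest of the two numbers; the one measured step, a 15-fold lower number from compound 1 to compound 2 (1.19 log units; beyond the scatter), runs away from it. Compound 3 `O=C1c2ccccc2S(=O)(=O)N1CCCCCCN1CCN(c2ccccn2)CC1` differs from compound 1 thus: pyridin-2-yl in place of 2-fluorophenyl on an amine nitrogen in a ring. Among the measured compounds shown here, the only step that bears on this is a 15-fold lower number from compound 1 to compound 2 (1.19 log units; beyond the scatter), yet it exchanges the same group for a different one, so it gives no direct guide. The expectation for compound 3 in this assay is therefore a 1.2-fold lower number from compound 1 to compound 3 (0.06 log units; within the scatter), with no step beyond the scatter. Compound 3 is estimated at 280 nM, range 70 nM to 1100 nM.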

Compound 3, inhibition constant: 552 nM
Compound 3: middle estimate off by 2.0-fold (0.29 log units), on the low side; the measured number falls inside the stated range.
By their numbers in this assay, from the lowest: compound 2; then compounds 1 and 3 (each within the scatter of the next).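

In this assay, pyridin-2-yl in place of 2-fluorophenyl on an amine nitrogen in a ring gives no change beyond the scatter (a 1.7-fold higher number from compound 1 to compound 3 (0.23 log units; within the scatter)). Pyridin-2-yl in place of quinolin-8-yl at the same place gives a large change (a 26-fold higher number from compound 2 to compound 3 (1.42 log units; beyond the scatter)), so among these three groups only quinolin-8-yl goes with the low number. No measurement at hand accounts for this difference.

The compounds shown leave open whether naphthalen-1-yl or unsubstituted phenyl at this place would give a number nearer compound 2 or nearer compounds 1 and 3.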